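The source may hold more compounds than are shown below. What is called first, only, known or untested is meant among the compounds shown, and "the series" means these compounds.

Working notes on the series. In an in vitro functional assay on HEK293-A cells for antagonist activity at metabotropic glutamate receptor 5 (Rattus norvegicus), read by calcium flux (on this read-out higher numbers stand for weaker inhibition and lower numbers for stronger inhibition), compound 2 `Cc1cccc(NC(=O)c2cc(F)cc(C#N)c2)c1` gives 122 nM, the higher of the two numbers in hand; compound 1 `N#Cc1cc(F)cc(C(=O)Nc2cccc(Cl)c2)c1` gives 45 nM in this assay. Within the data shown here, the single measured step so far is a 2.7-fold higher number from compound 1 to compound 2 (0.43 log units; beyond the scatter), and it is the only one that bears on the next change, since both steps alter the same substituent on the same ring.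

Compound 3 `N#Cc1cc(F)cc(C(=O)Nc2cccc(C(F)(F)F)c2)c1` differs from compound 2 by trifluoromethyl in place of methyl on an aromatic carbon. Among the measured compounds shown here, the measured step shows that a change at this position can move the number beyond the scatter, but only modestly, and no measured pair contains the trifluoromethyl group itself. The expected step in this assay is therefore a modest one, most likely back toward a lower number, with the direction not secure. The expected step is a 2.0-fold lower number from compound 2 to compound 3 (0.31 log units; beyond the scatter). Compound 3 is estimated at 60 nM, with a range of 20 nM to 200 nM.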

Compound 3, half-maximal inhibitory concentration: 543 nM
Beside the measured number, compound 3's estimate is 9.1-fold (0.96 log units) below it, and the stated range ends below it.
By their numbers in this assay, from the lowest: compound 1; then compound 2; then compound 3.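

In this assay, among these compounds, this position proves more sensitive than the single earlier step indicated: trifluoromethyl gives a 4.5-fold higher number from compound 2 to compound 3 (0.65 log units; beyond the scatter) and a 12-fold higher number from compound 1 to compound 3 (1.08 log units; beyond the scatter), the second of these a large step. Among the three groups on this aromatic carbon, chloro now stands with the lowest number and trifluoromethyl with the highest, while methyl lies between them, so the two halogen-bearing groups do not behave alike here. Nothing in hand accounts for this order.

The compounds shown leave open how other groups at this position would fall in this order, for example methoxy, bromo or an amine. They also leave open whether the same order would hold if the fluoro or nitrile on the shared core were changed.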